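The compounds below may be only part of what the source reports. "The series", "measured", "known", "first", "only" and "open" are said of these compounds alone.

Among the two compounds measured so far in a functional assay on NCI/ADR cells (Homo sapiens) for cytotoxicity, read by sulforhodamine B assay (a higher number here means a weaker inhibitor of growth, a lower number a stronger inhibitor of growth), compound 2 `CC1=CC[C@@H]([C@@](C)(O)CCCC(C)(C)NC(=S)N/N=C\c2ccc(N(C)C)cc2)CC1` stands highest with 25200 nM, while compound 1 `CC1=CC[C@@H]([C@@](C)(O)CCCC(C)(C)NC(=S)N/N=C\c2ccc(C)cc2)CC1` gives 6510 nM. Among the compounds with values here, the one step between them, a 3.9-fold higher number from compound 1 to compound 2 (0.59 log units; beyond the scatter), shows that swapping the group on the aromatic ring moves the number by a modest but real amount. Compound 3 `CC1=CC[C@@H]([C@@](C)(O)CCCC(C)(C)NC(=S)N/N=C\c2ccccc2[N+](=O)[O-])CC1` is the next compound of this series, and it differs from compound 2 by 2-nitrophenyl in place of 4-(dimethylamino)phenyl on a carbon with a double bond to nitrogen. The measured step from compound 1 to compound 2 is the only one that bears on this change, and it bears only loosely: it exchanged one substituent on the same aromatic ring, whereas here a different substituent enters, at another place on that ring. With that single, indirect precedent, a step of modest size is expected, more likely downward than upward, so that compound 3 is estimated at 11000 nM, within 4000 nM to 30000 nM, corresponding to a 2.3-fold lower number from compound 2 to compound 3 (0.36 log units; beyond the scatter).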

Compound 3, concentration for 50% growth inhibition: 20400 nM
Beside the measured number, compound 3's estimate is 1.9-fold (0.27 log units) below it; the measured number falls inside the stated range.
By their numbers in this assay, from the lowest: compound 1; then compounds 3 and 2 (each within the scatter of the next).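

Replacing 4-(dimethylamino)phenyl with 2-nitrophenyl on the carbon with a double bond to nitrogen gives a 1.2-fold lower number from compound 2 to compound 3 (0.09 log units; within the scatter) in this assay, so these two quite different groups cannot be told apart here. Measured against 4-methylphenyl, the same 2-nitrophenyl gives a 3.1-fold higher number from compound 1 to compound 3 (0.50 log units; beyond the scatter) and this leaves compound 1, the 4-methylphenyl member, as the strongest inhibitor of growth of the three, with the other two groups level. No measurement at hand explains these numbers.

Compound 3 differs from compound 2 in both the substituent and its place on the aromatic ring, so the two contributions cannot be separated. A 4-nitrophenyl or 2-methylphenyl group would pull them apart, and plain phenyl would show how the ring behaves with no substituent.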